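The source may hold more compounds than are shown below. What is called first, only, known or untested is meant among the compounds shown, and "the series" means these compounds.

For the measured compounds named here, in an assay on isolated protein for inhibition of matrix metalloproteinase-9 (Homo sapiens), read by fluorescence (a higher number here means a weaker inhibitor, a lower number a stronger inhibitor), compound 2 `COc1ccc(S(=O)(=O)N2C[C@H](NC(=O)CCCN)C[C@@H]2C(=O)NO)cc1` gives 53 nM, the second highest of the three numbers known here. Compound 1 `CCCC[C@H](N)C(=O)N[C@@H]1C[C@H](C(=O)NO)N(S(=O)(=O)c2ccc(OC)cc2)C1` gives 98 nM in this assay. Compound 3 `COc1ccc(S(=O)(=O)N2C[C@H](NC(=O)[C@H](CCCCN)NC(=O)OC(C)(C)C)C[C@@H]2C(=O)NO)cc1` gives 27 nM in this assay. Both of these stand within the usual scatter of compound 2. Compound 4 `COc1ccc(S(=O)(=O)N2C[C@H](NC(=O)[C@@H](N)CCCN)C[C@@H]2C(=O)NO)cc1` has not yet been measured; it differs from compound 2 in one place: 1,4-diaminobutyl in place of 3-aminopropyl on a carbonyl carbon. Going by the values given here, the only measured step that touches a chain on this carbonyl carbon is a 1.8-fold lower number from compound 1 to compound 2 (0.27 log units; within the scatter), which stayed inside the scatter, and the gap between compound 2 and compound 3 also lies inside it. For compound 4 a step no larger than the scatter is therefore expected, with an estimate of 45 nM in this assay, ranging from 20 nM to 110 nM, which would mean a 1.2-fold lower number from compound 2 to compound 4 (0.07 log units; within the scatter).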

Compound 4, half-maximal inhibitory concentration: 154 nM
Compound 4: the middle estimate sits 3.4-fold (0.53 log units) below what was measured; the measured number lies above the stated range.
By their numbers in this assay, from the lowest: compounds 3, 2, 1 and 4 (each within the scatter of the next, the first and the last beyond it).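

In this assay, the chain on this carbonyl carbon proves less tolerant of change than the earlier compounds suggested: 1,4-diaminobutyl in place of 3-aminopropyl gives a 2.9-fold higher number from compound 2 to compound 4 (0.46 log units; beyond the scatter), the only listed step beyond the scatter. By contrast, amino in place of methyl on a saturated chain carbon gives a 1.6-fold higher number from compound 1 to compound 4 (0.20 log units; within the scatter), which stays within the scatter. Nothing available explains either step.

The compounds shown leave open whether the step from 3-aminopropyl follows from the amine added to the chain, its length or its stereocentre. Going by these compounds, how a carboxylic acid or a longer chain without an amine would read at this carbonyl carbon also remains open.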